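The compounds below may be only part of what the source reports. "The series", "measured", "known", "first", "only" and "open" are said of these compounds alone.

Compound 2, `O=C(Nc1nc2ccc(Cl)cc2s1)c1cn(-c2ccccc2)nc1-c1ccc(F)cc1`, gives 3320 nM in a functional assay on HT-29 cells (Homo sapiens) for cytotoxicity, read by MTT assay, with a stated time of 72 h (on this read-out lower numbers stand for stronger inhibition and higher numbers for weaker inhibition), the lowest of the three measured numbers. Compound 1, `O=C(Nc1nc2ccccc2s1)c1cn(-c2ccccc2)nc1-c1ccc(F)cc1`, gives 9060 nM, and compound 3, `COc1ccc2nc(NC(=O)c3cn(-c4ccccc4)nc3-c3ccc(F)cc3)sc2c1`, gives 33200 nM. The steps among them were a 2.7-fold lower number from compound 1 to compound 2 (0.44 log units; beyond the scatter), a 3.7-fold higher number from compound 1 to compound 3 (0.56 log units; beyond the scatter) and a 10-fold higher number from compound 2 to compound 3 (1.00 log units; beyond the scatter).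

Compound 4, `O=C(Nc1nc2ccc(Cl)cc2s1)c1cn(-c2ccccc2)nc1-c1ccc(Cl)cc1`, differs from compound 2 by chloro in place of fluoro on an aromatic carbon. For the measured compounds named here, no measured step touches this ring; the only step that swaps in a chloro, a 2.7-fold lower number from compound 1 to compound 2 (0.44 log units; beyond the scatter), sits on the other ring and is modest. The halogen swap here is a small change, so in this assay little shift beyond the scatter is expected. Compound 4 is therefore estimated at 2800 nM, between 900 nM and 9000 nM, a step of a 1.2-fold lower number from compound 2 to compound 4 (0.07 log units; within the scatter).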

Compound 4, half-maximal inhibitory concentration: 4550 nM
Compound 4: the middle estimate sits 1.6-fold (0.21 log units) below what was measured; measured number inside the range.
By their numbers in this assay, from the lowest: compounds 2, 4 and 1 (each within the scatter of the next, the first and the last beyond it); then compound 3.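

This is the first change shown on this ring: going from 4-fluorophenyl to 4-chlorophenyl gives a 1.4-fold higher number from compound 2 to compound 4 (0.14 log units; within the scatter) in this assay and so does not separate the two halogens here. The earlier steps shown here all came from the other ring, where the changes moved the number beyond the scatter, as in a 2.7-fold lower number from compound 1 to compound 2 (0.44 log units; beyond the scatter). No measurement of any property bears on this result.

From the compounds shown here alone, whether an amine or a carboxylic acid at this position would shift the number stays open. So does whether fluoro and chloro would also match on the core of compound 1.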